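The compounds below may be only part of what the source reports. "The series", "measured", "known", "first", "only" and "open" are said of these compounds alone.

Measured compounds:
Compound 1, `C=CS(=O)(=O)NC/C=C/c1cc(OC)cc(O)c1C(=O)OC(C)C`: 14700 nM
Compound 2, `C=CS(=O)(=O)NC/C=C/c1cc(OC)cc(O)c1C(=O)OCC1CCCCC1`: 7880 nM

Both numbers come from a functional assay on THP-1 cells (Homo sapiens) for antiproliferative activity, read by luminescence, with a stated time of 72 h; a higher number here means a weaker inhibitor, a lower number a stronger inhibitor. Among the compounds with values here, compound 2 is one of only two compounds measured so far, and its number and that of compound 1 lie within the usual scatter of each other, so neither can be called the stronger or the weaker inhibitor on this evidence. Within the data shown here, the only measured step, a 1.9-fold lower number from compound 1 to compound 2 (0.27 log units; within the scatter), exchanges one saturated group on the ester oxygen for another and stays within the scatter.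

Compound 3, `C=CS(=O)(=O)NC/C=C/c1cc(OC)cc(O)c1C(=O)OCc1ccc(Br)cc1`, has not yet been measured in this assay . It differs from compound 2 in one place: 4-bromophenyl in place of cyclohexyl on a saturated chain carbon bound to an oxygen next to a carbonyl group. Among the measured compounds shown here, the one measured step concerns the same ester position and was within the scatter, but it did not exchange a saturated ring for an aromatic ring carrying bromine, so it bears only loosely on this change. With nothing in the measured pairs pointing in either direction, the expected step of a 1.1-fold lower number from compound 2 to compound 3 (0.05 log units; within the scatter) is none beyond the scatter, and compound 3 is estimated at 7000 nM, with a range from 2500 nM to 20000 nM.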

Compound 3, half-maximal inhibitory concentration: 6240 nM
For compound 3 the middle estimate is 1.1-fold (0.05 log units) above the measured one; the measured number falls inside the stated range.
By their numbers in this assay, from the lowest: compounds 3, 2 and 1 (each within the scatter of the next, the first and the last beyond it).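

In this assay, the position on the ester oxygen accepts an aromatic ring carrying bromine about as well as a saturated ring: the exchange of cyclohexyl for 4-bromophenyl gives a 1.3-fold lower number from compound 2 to compound 3 (0.10 log units; within the scatter), so the two groups cannot be told apart here. Within the data shown here, what is new is the comparison with the isopropyl ester, a 2.4-fold lower number from compound 1 to compound 3 (0.37 log units; beyond the scatter), the first step at this position to clear the scatter, although only modestly, and compound 2 stays within the scatter of both other compounds, so the three do not form a clear ladder. Nothing at hand gives a reason for either step.

On these data alone, it remains open whether the bromine contributes anything, which a plain benzyl group or a chlorine or methoxy group on the same ring could test. As far as these compounds go, the shared core also remains unexplored, as does the ester linkage itself, which could be tested by replacing it with an amide or a free carboxylic acid.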